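Benzylthio variation and cytotoxicity toward GES1 cells

A few compounds are considered here, and "the series" means these few. Any claim that something is new, unique, unknown or untested is made for them only; others in the source may bear on it.

Measured compounds:
compound 1 `Cc1cc(N2CC[C@@H](C)[C@@H](N(C)c3ncnc4[nH]ccc34)C2)n2nc(SCc3ccc(Cl)cc3)nc2n1`: > 100000 nM
compound 2 `Cc1cc(N2CC[C@@H](C)[C@@H](N(C)c3ncnc4[nH]ccc34)C2)n2nc(SCc3nc4ccccc4[nH]3)nc2n1`: 40200 nM
compound 3 `Cc1cc(N2CC[C@@H](C)[C@@H](N(C)c3ncnc4[nH]ccc34)C2)n2nc(SCc3ccc(F)cc3)nc2n1`: 12300 nM

In a toxicity assay on GES1 cells (Homo sapiens) for inhibition, read by MTT assay, with a stated time of 72 h (on this read-out lower numbers stand for stronger inhibition and higher numbers for weaker inhibition), compound 1 reaches only a limit, (the limit of > 100000 nM in this assay, at which 1 of the 3 values shown sits). Compound 2 gives 40200 nM and compound 3 gives 12300 nM, the lowest of the two numbers. Moving to compound 3 from compound 1 gives an at least 8.1-fold lower number from compound 1 to compound 3 (0.91 log units; beyond the scatter), and from compound 2 gives a 3.3-fold lower number from compound 2 to compound 3 (0.51 log units; beyond the scatter).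

Compound 4 `Cc1cc(N2CC[C@@H](C)[C@@H](N(C)c3ncnc4[nH]ccc34)C2)n2nc(SCc3cc(Cl)ccc3Cl)nc2n1` differs from compound 3 by 2,5-dichlorophenyl in place of 4-fluorophenyl on a saturated chain carbon bound to a sulfur. The step of an at least 8.1-fold lower number from compound 1 to compound 3 (0.91 log units; beyond the scatter) bears on it: chloro in place of fluoro raised the number beyond the limit, so a higher number is expected for compound 4, estimated at 35000 nM (range 9000 nM to 100000 nM), a step of a 2.8-fold higher number from compound 3 to compound 4 (0.45 log units; beyond the scatter).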

Compound 4, half-maximal inhibitory concentration: 87500 nM
The estimate for compound 4 lay 2.5-fold (0.40 log units) below the measured number; low and high end bracket the measured number.
By their numbers in this assay, from the lowest: compound 3; then compound 2; then compound 4. At a limit, above all of these: compound 1.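

Replacing 4-fluorophenyl with 2,5-dichlorophenyl gives a 7.1-fold higher number from compound 3 to compound 4 (0.85 log units; beyond the scatter), replacing 1H-benzimidazol-2-yl with it gives a 2.2-fold higher number from compound 2 to compound 4 (0.34 log units; beyond the scatter), and replacing 4-chlorophenyl with it gives an at least 1.1-fold lower number from compound 1 to compound 4 (0.05 log units; that floor lies within the scatter). Among the compounds shown, the two chlorine-bearing phenyl groups, in compound 1 and compound 4, both stand above compound 2 and compound 3, with no compound going against this. The value of compound 1 is a limit: the limit of > 100000 nM in this assay, at which 1 of the 4 values shown sits.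

From the compounds shown here alone, whether the count of chlorines or their placement sets the number remains open. Also open, going by these compounds, is how an amine or a carboxylic acid on the phenyl ring, or a longer chain on the sulfur, would read here.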